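The source may hold more compounds than are shown below. What is called first, only, known or untested is meant among the compounds shown, and "the series" means these compounds.

Measured compounds in a functional assay on MCF7 cells (Homo sapiens) for antiproliferative activity, read by MTT assay, with stated times of 24 h and 72 h; on this read-out lower numbers stand for stronger inhibition and higher numbers for weaker inhibition:
compound 1, `COc1cc(N2C(=O)[C@@H](Oc3ccccc3)[C@H]2c2cccc3ccccc23)cc(OC)c1OC`: 53000 nM
compound 2, `COc1cc(N2C(=O)[C@@H](Oc3ccccc3)[C@H]2c2ccc(SC)cc2)cc(OC)c1OC`: 7700 nM
compound 3, `COc1cc(N2C(=O)[C@@H](Oc3ccccc3)[C@H]2c2ccc(S(C)(=O)=O)cc2)cc(OC)c1OC`: 62000 nM

Compound 3 stands at the highest number of the three. Its step from compound 1 is small, a 1.2-fold higher number from compound 1 to compound 3 (0.07 log units; within the scatter), while the step from compound 2 is larger, an 8.1-fold higher number from compound 2 to compound 3 (0.91 log units; beyond the scatter), and that from compound 1 to compound 2 is a 6.9-fold lower number from compound 1 to compound 2 (0.84 log units; beyond the scatter).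

Compound 4, `COc1cc(N2C(=O)[C@@H](Oc3ccccc3)[C@H]2c2cc(N)c(OC)c(O)c2)cc(OC)c1OC`, differs from compound 3 in one place: a group of 10 heavy atoms (7 carbon, 1 nitrogen, 2 oxygen; one six-membered aromatic ring of carbon only) in place of a group of 10 heavy atoms (7 carbon, 2 oxygen, 1 sulfur; one six-membered aromatic ring of carbon only), on a saturated ring carbon. All three measured steps bear on it, since each exchanges the group on the same saturated ring carbon, and they show that such an exchange can leave the number unchanged or move it modestly in either direction. Within the data shown here, no measured compound carries the entering group, so its direction is not fixed by the data. A modest step, probably downward, is expected, a 2.1-fold lower number from compound 3 to compound 4 (0.32 log units; beyond the scatter). For compound 4 the estimated value in this assay is 30000 nM, within the range 6000 nM to 150000 nM.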

Compound 4, half-maximal inhibitory concentration: 8800 nM
Estimate against measurement, compound 4: 3.4-fold (0.53 log units) above; the measured number falls inside the stated range.
By their numbers in this assay, from the lowest: compounds 2 and 4 (each within the scatter of the next); then compounds 1 and 3 (each within the scatter of the next).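

In this assay, the saturated ring carbon of the four-membered ring holds two quite different aromatic groups at one level: a 1.1-fold higher number from compound 2 to compound 4 (0.06 log units; within the scatter). Compound 4 also parts clearly from the other two compounds, with a 7.0-fold lower number from compound 3 to compound 4 (0.85 log units; beyond the scatter) and a 6.0-fold lower number from compound 1 to compound 4 (0.78 log units; beyond the scatter), so a low number here does not depend on a sulfur-bearing group, since the entering group has none. Nothing measured here explains these steps.

The compounds shown do not separate the amino, hydroxyl and methoxy groups of the entering ring, so it remains open which of them, alone or together, goes with the step from compound 3. On these data alone, how a carboxylic acid or an ethylsulfanyl group would fare on that aromatic ring also remains open.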